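Swapping the side chain of compound 3

The source may hold more compounds than are shown below. What is called first, only, known or untested is meant among the compounds shown, and "the series" means these compounds.

In an ADME assay on MT4 cells (Homo sapiens) for cytotoxicity, read by MTT assay (a higher number here means that more compound is tolerated, a lower number that less compound is tolerated), compound 1 `Cc1cc(C)cc(S(=O)(=O)c2c(C(=O)Nc3cccc(O)c3)[nH]c3ccc(Cl)cc23)c1` gives 24600 nM, compound 2 `Cc1cc(C)cc(S(=O)(=O)c2c(C(=O)NCc3ccccc3N)[nH]c3ccc(Cl)cc23)c1` gives 46200 nM and compound 3 `Cc1cc(C)cc(S(=O)(=O)c2c(C(=O)NC(C)c3cccc(O)c3)[nH]c3ccc(Cl)cc23)c1` gives 16000 nM. Two steps show where compound 3 stands: a 1.5-fold lower number from compound 1 to compound 3 (0.19 log units; within the scatter), and a 2.9-fold lower number from compound 2 to compound 3 (0.46 log units; beyond the scatter). Compound 4 `Cc1cc(C)cc(S(=O)(=O)c2c(C(=O)NC(C)C(=O)NCc3cccc(O)c3)[nH]c3ccc(Cl)cc23)c1` carries (3-hydroxybenzyl)carbamoyl in place of 3-hydroxyphenyl on a saturated chain carbon bound to an amide-type nitrogen and a saturated chain carbon. Among the measured compounds shown here, no measured compound carries this group, so the only guide is the changes on the amide-type nitrogen, which stayed modest, as in a 1.9-fold higher number from compound 1 to compound 2 (0.27 log units; within the scatter) and the two steps above. No shift beyond the scatter is therefore expected in this assay, only an estimated 1.4-fold higher number from compound 3 to compound 4 (0.14 log units; within the scatter). For compound 4 the expected value is 22000 nM, with an estimated range of 9000 nM to 50000 nM.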

Compound 4, half-maximal cytotoxic concentration: 23800 nM
Beside the measured number, compound 4's estimate is 1.1-fold (0.03 log units) below it; the measured number falls inside the stated range.
By their numbers in this assay, from the lowest: compounds 3, 4, 1 and 2 (each within the scatter of the next, the first and the last beyond it).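

In this assay, replacing 3-hydroxyphenyl with (3-hydroxybenzyl)carbamoyl on the saturated chain carbon gives a 1.5-fold higher number from compound 3 to compound 4 (0.17 log units; within the scatter) for this swap. This place therefore accepts a group of 11 heavy atoms, including a carbonyl, instead of one of 7 heavy atoms, without the number moving beyond the scatter. The earlier compounds shown here showed only changes on the amide-type nitrogen, and one of those steps did go beyond the scatter.

Going by these compounds, whether an amine, a carboxylic acid or a longer chain on this carbon would behave the same stays open. Nothing available explains why the number holds here.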